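A few compounds are considered here, and "the series" means these few. Any claim that something is new, unique, unknown or untested is made for them only; others in the source may bear on it.

The measured compounds and their values in a functional assay on KB cells (Homo sapiens) for cytotoxicity, read by sulforhodamine B assay, with a stated time of 72 h; on this read-out higher numbers stand for an effect only at larger amounts of compound and lower numbers for an effect already at smaller amounts:
compound 1 `CCCC[C@H](OC(C)=O)[C@@H](O)[C@H](O)[C@@H]1OC(=O)C=C[C@@H]1OC(C)=O`: 5.9 ug/mL
compound 2 `CCCC[C@@H](/C=C\[C@@H]1OC(=O)C=C[C@@H]1O)OC(C)=O`: 1.7 ug/mL
compound 3 `CC(=O)O[C@H](/C=C\[C@H]1CC=CC(=O)O1)C[C@@H](OC(C)=O)[C@H](C)OC(C)=O`: 3.6 ug/mL

Among these three, compound 2 gives the lowest number in this assay. Its nearest neighbour is compound 3, whose value lies above it by a gap beyond the usual scatter, and the furthest is compound 1, which lies further off still. Compound 4 `CCCC[C@@H](/C=C\[C@@H]1OC(=O)C=C[C@@H]1OC(C)=O)OC(C)=O` has not yet been measured. It differs from compound 2 in one place: acetyl in place of hydrogen on an oxygen on a saturated carbon. Among the compounds with values here, no pair of measured compounds differs by this single change, so nothing measured tells how large such a step is. Compound 1 and compound 3 both give higher numbers than compound 2, but each differs from it in several places at once, so their values say nothing about this change on its own. On that basis the step from compound 2 to compound 4 in this assay is expected to be small, in either direction, and not beyond the scatter. Compound 4 is expected to give 2 ug/mL, within 0.8 ug/mL to 5 ug/mL. This expectation means a step of a 1.2-fold higher number from compound 2 to compound 4 (0.07 log units; within the scatter).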

Compound 4, concentration for half-maximal effect: 1.8 ug/mL
Beside the measured number, compound 4's estimate is 1.1-fold (0.05 log units) above it, and the stated range covers the measured number.
By their numbers in this assay, from the lowest: compounds 2, 4, 3 and 1 (each within the scatter of the next, the first and the last beyond it).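

In this assay, the change from hydroxy to acetoxy on an oxygen on a saturated carbon can now be read directly, and a 1.1-fold higher number from compound 2 to compound 4 (0.02 log units; within the scatter) stays within the scatter. At this place, then, the hydrogen of the hydroxy group is not needed to hold the number in this pair, and an acetyl group is accepted there without a change beyond the scatter. No measurement at hand bears on the reason for this result.

The compounds shown leave open whether the same holds for other groups on this oxygen, such as a methyl ether or a longer butyryl ester, or for an amine in place of the hydroxy. They also leave open whether acetyl in place of hydrogen has as small an effect on the other oxygens of the series.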